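This account rests on a few compounds, and the source may have more. Where it says the series, first, only, none or still open, it means among the compounds named here.

The compounds here share one core and differ mainly in the aromatic group attached to the carbon with a double bond to nitrogen at the far end of the chain. Compound 1 `COc1ccc(/C=N/NC(=O)Nc2ccc(Oc3ccnc(-c4nncn4CCN(C)C)c3)c(F)c2)c(OC)c1` carries a 2,4-dimethoxyphenyl there, and in a functional assay on MKN-45 cells (Homo sapiens) for cytotoxicity, read by MTT assay, with a stated time of 72 h (a higher number here means a weaker inhibitor, a lower number a stronger inhibitor), compound 1 gives 1680 nM, the lowest of the two numbers measured. Compound 2 `COc1ccc(/C=N/NC(=O)Nc2ccc(Oc3ccnc(-c4nncn4CCN(C)C)c3)c(F)c2)c(OC)c1OC` differs by a methoxy in place of hydrogen on an aromatic carbon; in this assay compound 2 gives 2020 nM, and the step of a 1.2-fold higher number from compound 1 to compound 2 (0.08 log units; within the scatter) stays within the scatter. Compound 3 `Cn1ncnc1-c1cc(Oc2ccc(NC(=O)N/N=C/c3ccccc3)cc2F)ccn1` is reported only as a limit, > 100000 nM, so the assay returned no number for it, as the line the limit of > 100000 nM in this assay, at which 1 of the 3 values shown sits, records. Compound 3 also differs from compound 1 in a second place, so its limit cannot be pinned on the aromatic group alone.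

Compound 4 `CN(C)CCn1cnnc1-c1cc(Oc2ccc(NC(=O)N/N=C/c3ccc(F)cc3)cc2F)ccn1` is reached from compound 1 by 4-fluorophenyl in place of 2,4-dimethoxyphenyl on a carbon with a double bond to nitrogen. For the measured compounds named here, the only measured step on this ring, the step from compound 1 to compound 2, was within the scatter, while compound 3, bare on this ring, sits at the limit. A moderate rise in the number is therefore expected, as the step of a 2.4-fold higher number from compound 1 to compound 4 (0.38 log units; beyond the scatter). Compound 4 is estimated at 4000 nM, with a range from 1200 nM to 25000 nM.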

Compound 4, half-maximal inhibitory concentration: 1030 nM
Beside the measured number, compound 4's estimate is 3.9-fold (0.59 log units) above it; measured number below the stated range.
By their numbers in this assay, from the lowest: compounds 4, 1 and 2 (each within the scatter of the next). At a limit, above all of these: compound 3.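

At the carbon with a double bond to nitrogen, the change is now larger than adding one methoxy: 4-fluorophenyl replaces the whole 2,4-dimethoxyphenyl, with fewer heavy atoms and no oxygen, and the result is a 1.6-fold lower number from compound 1 to compound 4 (0.21 log units; within the scatter). Against the 2,3,4-trimethoxyphenyl of compound 2, the result is a 2.0-fold lower number from compound 2 to compound 4 (0.29 log units; within the scatter), so this assay does not separate compound 1, compound 2 and compound 4, and none of the three stands out despite these different substituents on the ring. Nothing measured here explains this.

From the compounds shown here alone, whether an amine or a carboxylic acid on this ring would also leave the number in this range stays open. Going by these compounds, compound 3 is a limit and differs in a second place, so what a bare phenyl gives on the core of compound 1 is also open.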